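Aryl for Benzyl on the Ring Nitrogen: Cytotoxicity Outlook

This account rests on a few compounds, and the source may have more. Where it says the series, first, only, none or still open, it means among the compounds named here.

The study compares three compounds built on a shared core that carries a methylpiperazine-bearing chain. Compound 1 `CN1CCN(CCCNCc2cn(-c3ccc([N+](=O)[O-])cc3)nc2-c2ccc(OC(F)(F)F)cc2)CC1` gives 1600 nM in an ADME assay on Huh-7 cells (Homo sapiens) for cytotoxicity; on this read-out lower numbers stand for higher toxicity in this test and higher numbers for lower toxicity in this test. Compound 2 `Cc1ccccc1-c1nn(Cc2ccc(F)cc2)cc1CNCCN1CCN(C)CC1` reaches only a limit in this assay, > 20000 nM, so no number is known for it. Compound 2 is one of the two values that sit at the limit of > 20000 nM in this assay, at which 1 of the 2 values shown sits. Compound 3 `Cc1ccccc1-c1nn(-c2ccc(OC(F)(F)F)cc2)cc1CNCCN1CCN(C)CC1` differs from compound 2 by 4-(trifluoromethoxy)phenyl in place of 4-fluorobenzyl on an aromatic nitrogen. Going by the values given here, no measured pair of compounds differs in a single place, so the size of such a step cannot be read from the data. The step from compound 2 to compound 3 is expected to move toward higher toxicity, an at least 2.5-fold lower number from compound 2 to compound 3 (0.39 log units; beyond the scatter), likely beyond the scatter, with compound 1 at 1600 nM showing that this series does yield numbers in this assay. Compound 3 is expected at 8000 nM, within 2500 nM to 20000 nM, with a fair chance that only a limit is returned.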

Compound 3, half-maximal cytotoxic concentration: 17000 nM
Compound 3: middle estimate off by 2.1-fold (0.33 log units), on the low side; the measured number falls inside the stated range.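

With 4-(trifluoromethoxy)phenyl in place of 4-fluorobenzyl on an aromatic nitrogen, this assay returns a number for compound 3 rather than a limit. Compound 2 holds only a limit in this read-out: the limit of > 20000 nM in this assay, at which 1 of the 3 values shown sits. Going by these compounds, the change can therefore be given only as a floor, an at least 1.1-fold lower number from compound 2 to compound 3 (0.07 log units; that floor lies within the scatter), so the data show no shift beyond the usual scatter at this position, and the true size of the step remains unknown.

A 4-fluorophenyl or a 4-(trifluoromethoxy)benzyl group on the same nitrogen would be needed to tell the aryl-for-benzyl exchange apart from the exchange of fluorine for trifluoromethoxy on the ring. Compound 3 and compound 1 differ in more than one place, so the value of compound 1, 1600 nM, cannot be tied to any single change.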